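The source may report more compounds than this note shows. Statements on the series, on what has been measured and on what is new or still open speak of the compounds shown alone.

Of the compounds shown here, three sharing one core have been tested in a functional assay on BCG823 cells (Homo sapiens) for inhibition, read by MTT assay, with a stated time of 72 h; on this read-out lower numbers stand for stronger inhibition and higher numbers for weaker inhibition. Compound 1 `CN(C(=O)NC(=O)c1ccc(F)c(F)c1)c1nc(C(F)(F)F)c(C(=O)N/N=C/c2ccc(C(F)(F)F)cc2)s1` gives 3.85 ug/mL. Compound 2 `CN(C(=O)NC(=O)c1ccc(F)c(F)c1)c1nc(C(F)(F)F)c(C(=O)N/N=C/c2cccc(C(F)(F)F)c2)s1` gives 4.46 ug/mL, the highest of the three numbers, yet its neighbours sit close: compound 1 is nearest, and compound 3 `CN(C(=O)NC(=O)c1ccc(F)c(F)c1)c1nc(C(F)(F)F)c(C(=O)N/N=C/c2cc(C(F)(F)F)cc(C(F)(F)F)c2)s1` gives 3.51 ug/mL. The two measured steps are small: a 1.2-fold higher number from compound 1 to compound 2 (0.06 log units; within the scatter) and a 1.3-fold lower number from compound 2 to compound 3 (0.10 log units; within the scatter), both within the scatter, and both concern the aryl group at the carbon with a double bond to nitrogen.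

Compound 4 `CN(C(=O)NC(=O)c1c(F)cccc1F)c1nc(C(F)(F)F)c(C(=O)N/N=C/c2cccc(C(F)(F)F)c2)s1` is not yet measured. It differs from compound 2 at the other end of the molecule: 2,6-difluorophenyl in place of 3,4-difluorophenyl on a carbonyl carbon. Among the measured compounds shown here, no measured step touches this part of the structure, so nothing shows how a shift between the 3,4-difluorophenyl and the 2,6-difluorophenyl affects this assay. For the measured compounds named here, the only guide is that every change so far has stayed within the scatter. In this assay compound 4 is therefore expected to give about 4.5 ug/mL, within a range of 2.2 ug/mL to 9 ug/mL, with the expected change being a 1.0-fold higher number from compound 2 to compound 4 (0.00 log units; within the scatter).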

Compound 4, half-maximal inhibitory concentration: 25.9 ug/mL
For compound 4 the middle estimate is 5.8-fold (0.76 log units) below the measured one, and the stated range ends below it.
By their numbers in this assay, from the lowest: compounds 3, 1 and 2 (each within the scatter of the next); then compound 4.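

Moving the two fluorines on the aryl group at the carbonyl carbon gives, in this assay, a 5.8-fold higher number from compound 2 to compound 4 (0.76 log units; beyond the scatter) and is the only step shown that lies beyond the scatter. The earlier steps shown here all concerned the aryl group at the carbon with a double bond to nitrogen, whereas this one shows that the other end of the molecule can also shift the number, with weaker inhibition for the 2,6-difluorophenyl than for the 3,4-difluorophenyl, even though the two groups match in every count of atoms. Nothing available here explains this difference.

The 2,6-difluorophenyl is shown only with the 3-(trifluoromethyl)phenyl at the other end, which leaves open whether the step holds with other aryl groups there. Also open, as far as these compounds go, is how an unsubstituted phenyl, a chlorophenyl or a methoxyphenyl on the carbonyl carbon would compare.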